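Dimethyl Groups on the Pyrrolidine Amide of Compound 3

The compounds below may be only part of what the source reports. "The series", "measured", "known", "first", "only" and "open" are said of these compounds alone.

In an assay on isolated protein for inhibition of thyroid hormone receptor beta (Homo sapiens), read by fluorescence, with a stated time of 30 min (a higher number here means a weaker inhibitor, a lower number a stronger inhibitor), compound 1 `O=C(NCc1cccc(Cl)c1)c1cc(Cl)c2cn(CCn3cccn3)nc2c1` gives 225 nM.
In this assay compound 2 `CCCN(CC1CCOC1)C(=O)c1cc(OC)c2oc(NCc3cccc(Cl)c3)nc2c1` gives 12 nM.
In this assay compound 3 `COc1cc(C(=O)N2CCCC2)cc2nc(NCc3cccc(Cl)c3)oc12` gives 180 nM.

Compound 3 stands second highest of the three numbers; its value and that of compound 1 lie within the scatter of each other, while compound 2 sits well below it, shown by a 15-fold higher number from compound 2 to compound 3 (1.18 log units; beyond the scatter). Compound 4 `COc1cc(C(=O)N2CCC(C)(C)C2)cc2nc(NCc3cccc(Cl)c3)oc12` differs from compound 3 by 3,3-dimethylpyrrolidin-1-yl in place of pyrrolidin-1-yl on a carbonyl carbon. Among the compounds with values here, only the step from compound 2 to compound 3 bears on this carbonyl position, and it was large, so the amide substituent clearly matters in this assay. The present change is smaller than that one, so compound 4 is expected to show only a modest shift, a 1.8-fold lower number from compound 3 to compound 4 (0.26 log units; within the scatter), possibly within the scatter. Compound 4 is estimated at 100 nM, with a range from 30 nM to 350 nM.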

Compound 4, half-maximal inhibitory concentration: 40 nM
Estimate against measurement, compound 4: 2.5-fold (0.40 log units) above; the range from low to high includes it.
By their numbers in this assay, from the lowest: compound 2; then compound 4; then compounds 3 and 1 (each within the scatter of the next).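

Moving to 3,3-dimethylpyrrolidin-1-yl on the carbonyl carbon brings a 4.5-fold lower number from compound 3 to compound 4 (0.65 log units; beyond the scatter) in this assay and shows that this position responds to substitution on the pyrrolidine ring itself, not only to replacing the whole amine. The ((oxolan-3-yl)methyl)(propyl)amino group still gives the lower number, with a 3.3-fold higher number from compound 2 to compound 4 (0.52 log units; beyond the scatter) remaining as the gap, so the dimethyl groups close much but not all of the distance to compound 2.

Going by these compounds, whether a single methyl group, a hydroxyl group or a piperidine ring would act likewise stays open. Nothing available explains the shift.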